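Swapping the furan on a purine-based series for a hydroxyphenyl

The source may report more compounds than this note shows. Statements on the series, on what has been measured and on what is new or still open speak of the compounds shown alone.

Measured compounds:
- compound 1, `NC1CCC(Nc2nc(NCc3ccc(Br)cc3)c3ncn(C4CCCC4)c3n2)CC1`: 850 nM
- compound 2, `NC1CCC(Nc2nc(NCc3ccc(-c4ccccc4)cc3)c3ncn(C4CCCC4)c3n2)CC1`: 583 nM
- compound 3, `NC1CCC(Nc2nc(NCc3ccc(-c4ccco4)cc3)c3ncn(C4CCCC4)c3n2)CC1`: 85 nM

In a functional assay on MCF7 cells (Homo sapiens) for inhibition, with a stated time of 72 h (a higher number here means a weaker inhibitor, a lower number a stronger inhibitor), compound 3 has the lowest number of the three. Its nearest neighbour is compound 2, with the step of a 6.9-fold lower number from compound 2 to compound 3 (0.84 log units; beyond the scatter) lying beyond the scatter, and compound 1 stands furthest away, with a 10-fold lower number from compound 1 to compound 3 (1.00 log units; beyond the scatter) also beyond the scatter. Compound 1 and compound 2 are separated only by a 1.5-fold lower number from compound 1 to compound 2 (0.16 log units; within the scatter), which is within the scatter.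

Compound 4, `NC1CCC(Nc2nc(NCc3ccc(-c4ccccc4O)cc3)c3ncn(C4CCCC4)c3n2)CC1`, differs from compound 3 in one place: 2-hydroxyphenyl in place of furan-2-yl on an aromatic carbon. The closest guide is compound 2, where the same kind of six-membered carbon ring sits in that position without the hydroxyl, and the step of a 6.9-fold lower number from compound 2 to compound 3 (0.84 log units; beyond the scatter) shows how much the furan-2-yl gained over it. Among the compounds with values here, no measured compound carries a hydroxyl on that ring, so the effect of the added hydroxyl is unknown. The expectation is that compound 4 lands between compound 2 and compound 3, a step of a 2.9-fold higher number from compound 3 to compound 4 (0.47 log units; beyond the scatter) in this assay, giving an estimated 250 nM with a range from 70 nM to 900 nM.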

Compound 4, half-maximal inhibitory concentration: 2910 nM
Compound 4: middle estimate off by 12-fold (1.07 log units), on the low side, and the stated range ends below it.
By their numbers in this assay, from the lowest: compound 3; then compounds 2 and 1 (each within the scatter of the next); then compound 4.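

In this assay, a hydroxy group added to the outer phenyl ring makes the compound weaker, a 5.0-fold higher number from compound 2 to compound 4 (0.70 log units; beyond the scatter), so this position responds to a single small addition on that ring and not only to the choice of ring. The change from the furan-2-yl is much larger, a 34-fold higher number from compound 3 to compound 4 (1.53 log units; beyond the scatter), and the 2-hydroxyphenyl also does worse than the original bromo, a 3.4-fold higher number from compound 1 to compound 4 (0.53 log units; beyond the scatter), so here it is no substitute for the furan-2-yl and loses even to the simple halogen. Nothing available on these compounds accounts for this loss.

As far as these compounds go, it remains open whether a methoxy group, an amine or a fluorine atom on the phenyl ring would weaken the compound as the hydroxy does. From the compounds shown here alone, it is also open whether other five-membered rings, such as thiophene or pyrrole, would match the furan-2-yl.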